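The source may hold more compounds than are shown below. What is called first, only, known or untested is meant among the compounds shown, and "the series" means these compounds.

Values in an ADME assay on PBMC cells (Homo sapiens) for cytotoxicity; on this read-out lower numbers stand for higher toxicity in this test and higher numbers for lower toxicity in this test:

compound 1 `CCO/N=C(/c1ccc(Br)cc1)C1CCN(C(C)CCNC(=O)c2c(Cl)cncc2Cl)CC1`: 33800 nM
compound 2 `CC(CCNC(=O)c1c(Cl)cncc1Cl)N1CCC(C(Oc2cccc(Cl)c2)c2ccc(C(F)(F)F)cc2)CC1`: 8100 nM
compound 3 `CCO/N=C(/c1ccc(Br)cc1)C1CCN(C(C)CNC(=O)c2c(C)cc[n+]([O-])c2C)CC1`: 182000 nM

Compound 2 gives the lowest number of the three in this assay. Compound 1 lies above it by a margin beyond the scatter, and compound 3 lies further above it still, also beyond the scatter. No pair among these three differs in a single place, so no isolated step can be read from the measured set; the spread only shows that the series reaches from the number of compound 2 to the much higher number of compound 3.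

Compound 4 `COC(=O)c1cccc(OC(c2ccc(C(F)(F)F)cc2)C2CCN(C(C)CCNC(=O)c3c(Cl)cncc3Cl)CC2)n1` has not been measured. It is built on compound 2 with one change: 6-(methoxycarbonyl)pyridin-2-yl in place of 3-chlorophenyl on an oxygen on a saturated carbon. The change leaves the rest of the structure untouched, including the amide and the piperidine-bearing chain shared with compound 1.

Among the compounds with values here, with no single-point step to lean on, the expectation for this assay is a modest move towards a higher number, most likely beyond the scatter but well short of the gap to compound 3. The step from compound 2 to compound 4 is expected at a 2.5-fold higher number from compound 2 to compound 4 (0.39 log units; beyond the scatter). Compound 4 is estimated at 20000 nM, with a range from 6000 nM to 65000 nM.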

Compound 4, half-maximal cytotoxic concentration: 14600 nM
Compound 4: the middle estimate sits 1.4-fold (0.14 log units) above what was measured; measured number inside the range.
By their numbers in this assay, from the lowest: compounds 2 and 4 (each within the scatter of the next); then compound 1; then compound 3.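

In this assay, within the data shown here, the first one-place comparison of the series reads a 1.8-fold higher number from compound 2 to compound 4 (0.26 log units; within the scatter), so this read-out does not separate the two compounds. On an oxygen on a saturated carbon, 6-(methoxycarbonyl)pyridin-2-yl can therefore stand in for 3-chlorophenyl without a change beyond the scatter, even though the entering group loses the chlorine, brings a ring hetero atom and has 3 hydrogen-bond acceptors where the leaving group has 0. Nothing measured here bears on why the two compounds read alike.

Going by these compounds, the ring nitrogen and the methoxycarbonyl enter together in this single step, so their separate contributions remain unresolved, and it is open whether a pyridin-2-yl carrying no methoxycarbonyl would read the same. Also open, on these data alone, is whether a free carboxylic acid, an amine or the longer ethoxycarbonyl in place of the methoxycarbonyl would stay within the scatter of compound 2 in this assay or move the number beyond it.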